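Fluoro for tert-butyl: a small step expected

A few compounds are considered here, and "the series" means these few. Any claim that something is new, unique, unknown or untested is made for them only; others in the source may bear on it.

Measured so far in a functional assay on SK-MEL-28 cells (Homo sapiens) for inhibition, read by MTT assay, with a stated time of 48 h; on this read-out higher numbers stand for weaker inhibition and lower numbers for stronger inhibition
compound 1 `O=C1N/C(=N\Cc2cccc(Cl)c2)S/C1=C1/CCNC(=O)c2[nH]ccc21` gives 34700 nM
compound 2 `O=C1N/C(=N\Cc2ccccc2Cl)S/C1=C1/CCNC(=O)c2[nH]ccc21` gives > 100000 nM (a limit of the assay, not a number)
compound 3 `CC(C)(C)c1ccc(C/N=C2\NC(=O)/C(=C3\CCNC(=O)c4[nH]ccc43)S2)cc1` gives 23500 nM

In this assay compound 3 (23500 nM) and compound 1 (34700 nM) lie within the usual scatter of each other, so neither can be ranked ahead. Compound 4 `O=C1N/C(=N\Cc2ccc(F)cc2)S/C1=C1/CCNC(=O)c2[nH]ccc21` has not yet been measured. It differs from compound 3 in one place (fluoro in place of tert-butyl on an aromatic carbon): fluoro in place of tert-butyl on an aromatic carbon, para to a large group.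

Within the data shown here, only one measured step changes a group in this part of the molecule (an at least 2.8-fold higher number from compound 1 to compound 2 (0.45 log units; beyond the scatter)). It shows that such a change can shift the read-out, but it replaces 3-chlorophenyl with 2-chlorophenyl and says nothing directly about losing tert-butyl. Compound 1 and compound 3 carry different groups, yet their values stay within the scatter, and this points to a modest change here. A result at the limit of > 100000 nM in this assay, at which 1 of the 3 values shown sits, cannot be ruled out, so the expectation leans towards a higher number. The expected size is a 1.7-fold higher number from compound 3 to compound 4 (0.23 log units; within the scatter) and remains uncertain. Compound 4 is estimated at 40000 nM in this assay with an expected range from 15000 nM to 90000 nM.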

Compound 4, half-maximal inhibitory concentration: 11200 nM
Beside the measured number, compound 4's estimate is 3.6-fold (0.55 log units) above it, outside the stated range (below it).
By their numbers in this assay, from the lowest: compound 4; then compounds 3 and 1 (each within the scatter of the next). At a limit, above all of these: compound 2.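

In this assay, fluoro, a single heavy atom, in place of tert-butyl, with 4 heavy atoms, on the aromatic carbon gives a 2.1-fold lower number from compound 3 to compound 4 (0.32 log units; beyond the scatter), a modest step towards stronger inhibition, so this position does not need the larger group for the activity seen here. Compound 4 also separates from a chlorine-bearing analogue, which compound 3 could not do, with a 3.1-fold lower number from compound 1 to compound 4 (0.49 log units; beyond the scatter), and it now holds the lowest number of the four compounds. Compound 2 stands at a limit of the assay, not a number, so its comparison gives only a bound, an at least 8.9-fold lower number from compound 2 to compound 4 (0.95 log units; beyond the scatter): the limit of > 100000 nM in this assay, at which 1 of the 4 values shown sits.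

The compounds shown leave open whether fluoro itself contributes or whether the gain comes simply from losing tert-butyl, and a plain hydrogen, a methoxy group or an amine on the same carbon would help tell these apart. A chloro group on that carbon would also show how much depends on the halogen and how much on its place on the ring, which compound 1 and compound 2 cannot show alone.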